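This account rests on a few compounds, and the source may have more. Where it says the series, first, only, none or still open, it means among the compounds named here.

Working notes on the series. All three measured compounds share the core of compound 1 `C=C1C(=O)O[C@@H](c2c(F)c(F)c(F)c(F)c2F)[C@H]1C`, which in a functional assay on BXPC-3 cells (Homo sapiens) for cytotoxicity, read by MTT assay, with a stated time of 72 h, tested at 1 uM (a higher number here means a weaker effect of the compound at the concentration tested, a lower number a stronger effect), gives 98%. Compound 2 `C=C1C(=O)O[C@H](c2ccccc2)[C@H]1c1ccccc1` carries a phenyl on each side of the shared core and in this assay gives 86%. Compound 3 `C=C1C(=O)O[C@H](c2ccc(OC)cc2)[C@H]1c1ccccc1` adds a methoxy to one of those phenyl rings and in this assay gives 73%, the lowest number of the three; the step of a number 13 percentage points lower from compound 2 to compound 3 (beyond the scatter) lies beyond the scatter, and the value of compound 1 stands higher still than that of compound 3, also beyond the scatter.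

Compound 4 `C=C1C(=O)O[C@H](c2ccc(C)cc2)[C@H]1c1ccccc1` is not yet measured. It differs from compound 3 in one place: methyl in place of methoxy on an aromatic carbon. Among the compounds with values here, the only measured step that bears on this position is a number 13 percentage points lower from compound 2 to compound 3 (beyond the scatter), which concerns methoxy entering where hydrogen had been. Here the methoxy leaves and a methyl, not hydrogen, enters; no step from hydrogen to methyl or from methoxy to methyl has been measured. The number for compound 4 is therefore expected to lie between those of compound 2 and compound 3, a step upward that may or may not reach beyond the scatter.

Compound 4 is estimated at 79%, with a range from 66% to 92%. This estimate means an expected step of a number 6 percentage points higher from compound 3 to compound 4 (within the scatter).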

Compound 4, a percentage reported as activity, at one concentration (the size of the read-out at that concentration, not a potency): 67%
Beside the measured number, compound 4's estimate is 12 percentage points above it; low and high end bracket the measured number.
By their numbers in this assay, from the lowest: compounds 4 and 3 (each within the scatter of the next); then compound 2; then compound 1.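

Methyl in place of methoxy gives a number 6 percentage points lower from compound 3 to compound 4 (within the scatter) in this assay and so leaves the two groups indistinguishable at this place, on an aromatic carbon para to a large group. Methyl in place of hydrogen gives a number 19 percentage points lower from compound 2 to compound 4 (beyond the scatter) and so shows that the lower number seen with methoxy is not confined to that group: a substituent with no oxygen and no hydrogen-bond acceptor also stands beyond the scatter of the unsubstituted phenyl ring of compound 2. Nothing at hand explains why either group gives this result.

Within the data shown here, still open is how far this tolerance extends, since only two small groups appear at this place; an ethyl or longer chain, a chlorine atom, an amine or a carboxylic acid there could show whether the number keeps falling, stays level or returns towards that of compound 2. Also open, going by these compounds, is whether methyl or methoxy would give a similar step at another place on this ring or on the second phenyl ring.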